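Butyl on the piperazine of compound 2

A few compounds are considered here, and "the series" means these few. Any claim that something is new, unique, unknown or untested is made for them only; others in the source may bear on it.

In a functional assay on SH-SY5Y cells (Homo sapiens) for cytotoxicity, read by MTT assay, with a stated time of 72 h (on this read-out lower numbers stand for stronger inhibition and higher numbers for weaker inhibition), compound 1 `O=C1c2c[n+]([O-])c3ccccc3c2C(=O)c2c1c1ccccc1n2CCCCn1ccnc1` gives 130 nM and compound 2 `O=C1c2c[n+]([O-])c3ccccc3c2C(=O)c2c1c1ccccc1n2CCCCN1CCNCC1` gives 1240 nM. Compound 2 therefore holds the higher of the two numbers and is the weaker of the measured compounds.

Compound 3 `CCCCN1CCN(CCCCn2c3c(c4ccccc42)C(=O)c2c[n+]([O-])c4ccccc4c2C3=O)CC1` differs from compound 2 by one change: butyl in place of hydrogen on an amine nitrogen in a ring. This places butyl in place of hydrogen on an amine nitrogen in a ring, turning piperazin-1-yl into 4-butylpiperazin-1-yl.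

Among the compounds with values here, only one measured step bears on this: a 9.5-fold higher number from compound 1 to compound 2 (0.98 log units; beyond the scatter). It is a modest step, beyond the scatter, and comes from piperazin-1-yl in place of 1H-imidazol-1-yl. It shows that the read-out in this assay can move with the group at the end of the chain, but it exchanges the whole group. Within the data shown here, no measured compound carries a substituent on the piperazine nitrogen, so the direction remains tentative. A smaller step than that one is expected, towards a lower number, and no change cannot be excluded. The expected step is a 2.3-fold lower number from compound 2 to compound 3 (0.35 log units; beyond the scatter).

For compound 3 the estimate is 550 nM, with an expected range of 170 nM to 1800 nM.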

Compound 3, half-maximal inhibitory concentration: 6100 nM
Beside the measured number, compound 3's estimate is 11-fold (1.04 log units) below it, and the stated range ends below it.
By their numbers in this assay, from the lowest: compound 1; then compound 2; then compound 3.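

In this assay, the amine nitrogen of the piperazine ring now carries a substituent for the first time in the compounds shown, and butyl in place of hydrogen gives a 4.9-fold higher number from compound 2 to compound 3 (0.69 log units; beyond the scatter), a step beyond the scatter. Within the data shown here, this settles the direction for this one change: in this pair, substitution at that nitrogen moves the number upwards, whereas the earlier step could show only that exchanging the whole group at the end of the chain matters. Read against the imidazole end group, the full exchange gives a 47-fold higher number from compound 1 to compound 3 (1.67 log units; beyond the scatter), a large step that leaves compound 1 with the lowest number of the three and shows that the two changes at the end of the chain run the same way, but nothing measured alongside these numbers accounts for the rise.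

The compounds shown leave open whether the rise tracks the size of the substituent, as a single butyl group gives no trend, and methyl or a longer chain such as hexyl on the same nitrogen would begin to test this. They also leave open whether a 2-hydroxyethyl group or an acetyl group at this nitrogen would move the number in the same direction as butyl.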